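Removing a Trifluoroacetyl Amide from a Stable Pyrrolidine Series

The source may report more compounds than this note shows. Statements on the series, on what has been measured and on what is new or still open speak of the compounds shown alone.

Compound 1: `CC(=O)N[C@@H]1CCN(c2cc(C)nn3c(-c4ccc5cc[nH]c5c4)c(C)nc23)C1` gives > 95%
Compound 2: `COc1ccc(-c2c(C)nc3c(N4CC[C@@H](NC(=O)C(F)(F)F)C4)cc(C)nn23)cc1OC` gives > 95%

Of the compounds shown here, two have been measured in an ADME assay on microsomes from liver (Homo sapiens) for metabolic stability, read by LC-MS, with NADPH named in the record, with a stated time of 60 min, tested at 1 uM, in the absence of a further agent; on this read-out higher numbers stand for a more stable compound and lower numbers for a less stable compound. Compound 1 `CC(=O)N[C@@H]1CCN(c2cc(C)nn3c(-c4ccc5cc[nH]c5c4)c(C)nc23)C1` gives > 95% in this assay, and this value is a limit of the assay rather than a number. Compound 2 `COc1ccc(-c2c(C)nc3c(N4CC[C@@H](NC(=O)C(F)(F)F)C4)cc(C)nn23)cc1OC` gives > 95% in this assay, and this too is a limit. So compound 2 stands at the upper limit of what this assay reports, as does the only other measured compound; (the limit of > 95% in this assay, at which 2 of the 2 values shown sit).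

Compound 3 `COc1ccc(-c2c(C)nc3c(N4CCCC4)cc(C)nn23)cc1OC` has not been measured. It differs from compound 2 in one place: hydrogen in place of ((trifluoromethyl)carbonyl)amino on a saturated ring carbon. The amide that carries the trifluoromethyl group is gone, leaving a bare five-membered saturated ring.

Among the measured compounds shown here, because both measured compounds sit at the limit, no measured step in this assay shows how large a change of this kind matters. A step from the limit can only be downward or none beyond the scatter; a modest loss is expected, since the ring left behind has no substituent at that carbon. Compound 3 is expected to give 82% in this assay, between 55% and 95%. The expected step is a number at least 13 percentage points lower from compound 2 to compound 3 (beyond the scatter).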

Compound 3, percent of the compound remaining: > 95%
Compound 3 gave a limit, no number; the forecaster's own chance of this, stated with the estimate: 40%; middle value at least 13 percentage points from the limit.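

In this assay compound 3 gives > 95% as a limit and not a number. Among the compounds shown here, compound 2 also sits at a limit, so no step between compound 2 and compound 3 can be read: the limit of > 95% in this assay, at which 3 of the 3 values shown sit. The compounds shown leave open whether replacing the ((trifluoromethyl)carbonyl)amino group with hydrogen changes stability at all.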